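Shifting a Fluorophenyl Substituent: A Cautious Forecast

A few compounds are considered here, and "the series" means these few. Any claim that something is new, unique, unknown or untested is made for them only; others in the source may bear on it.

Compound 1 `Oc1ccc(-c2cc(-c3ccccc3F)cc(-c3ccccc3O)n2)cc1` and compound 2 `Oc1ccc(-c2cc(-c3cccc(F)c3)cc(-c3ccccc3O)n2)cc1` share one core and differ only by 3-fluorophenyl in place of 2-fluorophenyl on an aromatic carbon. In a functional assay on HCT-15 cells (Homo sapiens) for inhibition (a higher number here means a weaker inhibitor, a lower number a stronger inhibitor), compound 1 gives > 50000 nM, which is a limit of the assay rather than a number. Compound 2 gives > 50000 nM, likewise a limit. The step that the two limits leave unreadable from compound 1 to compound 2 therefore cannot be sized because both values sit at the limit of > 50000 nM in this assay, at which 2 of the 3 values shown sit. Compound 3 `Oc1cccc(-c2cc(-c3ccccc3F)cc(-c3cccc(O)c3)n2)c1` carries another core; the difference between the two cores is not broken down here. In this assay, within the data shown here, compound 3 gives 5300 nM, the only number among the three. Compound 4 `Oc1cccc(-c2cc(-c3cccc(F)c3)cc(-c3cccc(O)c3)n2)c1` arises from compound 3 by 3-fluorophenyl in place of 2-fluorophenyl on an aromatic carbon, the same kind of change as from compound 1 to compound 2, though the place differs: meta to two 3-hydroxyphenyl groups rather than meta to a 2-hydroxyphenyl group and a 4-hydroxyphenyl group. The earlier step offers no readable size, so the expectation rests on compound 3 and its value 5300 nM. The expected step of a 1.1-fold higher number from compound 3 to compound 4 (0.05 log units; within the scatter) is set near zero with wide uncertainty. Compound 4 is estimated at 6000 nM.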

Compound 4, half-maximal inhibitory concentration: 7860 nM
The estimate for compound 4 lay 1.3-fold (0.12 log units) below the measured number; the range from low to high includes it.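

In this assay, the change gives a 1.5-fold higher number from compound 3 to compound 4 (0.17 log units; within the scatter), so on the core of compound 3 the 2-fluorophenyl and 3-fluorophenyl groups cannot be told apart. Among these compounds, this shows only that the change has no readable effect on that one core, at that one place. It does not show that the change carries across cores, since its size on the core of compound 1 cannot be read: the limit of > 50000 nM in this assay, at which 2 of the 4 values shown sit.

The compounds shown leave open whether any group at the place opposite the ring nitrogen would give a step beyond the scatter. An amine or a carboxylic acid there, in place of the fluorophenyl group, would be one test of this.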